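Swapping sec-butyl for 1-methoxy-1-methylethyl in compound 3

The source may hold more compounds than are shown below. What is called first, only, known or untested is meant among the compounds shown, and "the series" means these compounds.

Measured so far in an in vitro ADME assay on microsomes from liver (Homo sapiens) for metabolic stability, tested at 5 uM; a lower number here means that the compound disappears faster, a higher number that the compound lasts longer:

- Compound 1 `CC(C)CCn1nc(CC2CCC2)c(O)c(C2=NS(=O)(=O)c3cc(NS(C)(=O)=O)ccc3N2)c1=O`: 0.417 h
- Compound 2 `C/C(=C\c1nn(CCC(C)C)c(=O)c(C2=NS(=O)(=O)c3cc(NS(C)(=O)=O)ccc3N2)c1O)C(F)(F)F`: 0.167 h
- Compound 3 `CCC(C)CCn1nc(-c2cccs2)c(O)c(C2=NS(=O)(=O)c3cc(NS(C)(=O)=O)ccc3N2)c1=O`: > 1 h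

For compound 3 the reading > 1 h is a limit and not a number. Compound 3 stands at the limit of > 1 h in this assay, at which 1 of the 3 values shown sits.

Compound 4 `COC(C)(C)CCn1nc(-c2cccs2)c(O)c(C2=NS(=O)(=O)c3cc(NS(C)(=O)=O)ccc3N2)c1=O` differs from compound 3 in one place: it carries 1-methoxy-1-methylethyl in place of sec-butyl on a saturated chain carbon, two bonds along the chain from an aromatic nitrogen.

For the measured compounds named here, only one measured step is available as a guide. It is a 2.5-fold lower number from compound 1 to compound 2 (0.40 log units; beyond the scatter), and it replaces a group on an aromatic carbon, not on the saturated chain. It therefore gives only a rough sense of how far one change can move this assay, and it says nothing about direction here. Going by the values given here, no measured pair tests the new group, so no step beyond the scatter is expected, though this is a weak expectation. The estimated step is a number no higher from compound 3 to compound 4 (the limit leaves the size open). A reading that again gives only a limit is quite possible. For compound 4 the expected half-life is 1 h, with an estimated range of 0.4 h to 2.5 h.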

Compound 4, half-life: > 1 h
Compound 4 ended at the assay's limit; the forecaster's own chance of this, stated with the estimate: 50%; the middle value sits exactly at the limit.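

In this assay, compound 3 and compound 4 both give a limit and not a number, so no step can be read between them: the limit of > 1 h in this assay, at which 2 of the 4 values shown sit. The compounds shown leave open how the actual half-lives of compound 3 and compound 4 compare, and so whether 1-methoxy-1-methylethyl in place of sec-butyl changes the reading at all.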